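This account rests on a few compounds, and the source may have more. Where it says the series, first, only, none or still open, it means among the compounds named here.

Compound 1 `CC(=O)Nc1cc(-c2ccc(N(C)C(=O)c3c(F)cccc3Cl)c(N3CCCCC3)c2)n(C(C)C)n1`: 1.3 ug/mL
Compound 2 `CN(C(=O)c1c(F)cccc1Cl)c1ccc(-c2cc(C(N)=O)ccc2Cl)cc1OCC(F)(F)F`: 0.3 ug/mL

Both compounds were tested in a physicochemical assay for solubility, measured as kinetic solubility; on this read-out lower numbers stand for lower solubility and higher numbers for higher solubility. Compound 2 has the lower of the two numbers, and its gap to compound 1 lies beyond the usual scatter. Compound 3 `CC(C)n1nc(C(N)=O)cc1-c1ccc(N(C)C(=O)c2c(F)cccc2Cl)c(OCC(F)(F)F)c1` has not yet been measured. It carries 3-carbamoyl-1-isopropyl-1H-pyrazol-5-yl in place of 5-carbamoyl-2-chlorophenyl on an aromatic carbon. Going by the values given here, no measured pair shows this exchange, so any expectation is loose. Compound 1, which also holds a five-membered aromatic ring with 2 hetero atoms, gives 1.3 ug/mL, and on that basis a rise beyond the scatter in this assay is expected rather than a fall. The expected change is a 5.0-fold higher number from compound 2 to compound 3 (0.70 log units; beyond the scatter). For compound 3 the estimated value is 1.5 ug/mL, with an expected range from 0.4 ug/mL to 6 ug/mL.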

Compound 3, solubility: 32 ug/mL
The estimate for compound 3 lay 21-fold (1.33 log units) below the measured number; the whole stated range lies below it.
By their numbers in this assay, from the lowest: compound 2; then compound 1; then compound 3.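

In this assay, putting 3-carbamoyl-1-isopropyl-1H-pyrazol-5-yl in place of 5-carbamoyl-2-chlorophenyl, on the aromatic carbon meta to a 2,2,2-trifluoroethoxy group, gives a 110-fold higher number from compound 2 to compound 3 (2.03 log units; beyond the scatter). Going by these compounds alone, this is the first single-place comparison in the set, and it shows that the number is highly sensitive to the group at this position. A carbamoyl group is present on both sides of the exchange, so the step goes with the change of ring and the other ring substituents, and nothing available explains it.

Within the data shown here, the single step cannot separate the contribution of the five-membered ring from the loss of the chlorine or the arrival of the isopropyl group. It also leaves open whether a methyl group in place of the isopropyl, or a carboxylic acid in place of the carbamoyl group, would preserve the higher number.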